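Swapping a halogenated pyridine on a chemokine receptor ligand

A few compounds are considered here, and "the series" means these few. Any claim that something is new, unique, unknown or untested is made for them only; others in the source may bear on it.

Measured so far:
compound 1, `Fc1cccc(NCc2ccc(CNc3cccc(F)n3)cc2)n1`, 100 nM
compound 2, `Clc1cccc(NCc2ccc(CNc3ncccn3)cc2)n1`, 1 nM

In an assay on MDA-MB-231 cells for displacement of a labelled ligand from C-X-C chemokine receptor type 4 (Homo sapiens) (a higher number here means that more compound is needed for the effect, a lower number that less compound is needed), compound 2 gives 1 nM, the lowest of the two numbers in hand. Its nearest neighbour is compound 1, which gives 100 nM, a gap well beyond the usual scatter; the two differ in two places, so which change drives the gap cannot be told from these data.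

Compound 3, `Fc1ccc(NCc2ccc(CNc3ncccn3)cc2)nc1`, is not yet measured. It differs from compound 2 in one place: 5-fluoropyridin-2-yl in place of 6-chloropyridin-2-yl on an amine nitrogen. Among the measured compounds shown here, no measured pair isolates this kind of swap, so the size of its effect is not known.

With a halogen kept on the same ring, only a modest loss relative to compound 2 is expected, and the step from compound 2 to compound 3 is estimated as a 5.0-fold higher number from compound 2 to compound 3 (0.70 log units; beyond the scatter). Compound 3 is expected to give about 5 nM, within a range of 1 nM to 30 nM.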

Compound 3, effective concentration (reported as EC, without a stated level of effect): 1 nM
Compound 3: middle estimate off by 5.0-fold (0.70 log units), on the high side; low and high end bracket the measured number.
By their numbers in this assay, from the lowest: compounds 2 and 3 (each within the scatter of the next); then compound 1.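

In this assay, putting 5-fluoropyridin-2-yl in place of 6-chloropyridin-2-yl on the amine nitrogen gives no change at the digits printed from compound 2 to compound 3 (within the scatter), with the rest of the molecule unchanged. Among the compounds shown here, this is the first pair that differs in one place, and it shows that this position accepts both of these halogenated pyridines without a step that can be told from the scatter. No measurement in hand bears on why these two groups give matching numbers.

As far as these compounds go, both groups carry a halogen, so it remains open whether a plain pyridine ring without one, or a pyridine bearing a methoxy group or an amine, would hold the number at this level. The pyrimidine ring on the other amine nitrogen has also not been varied on its own in any pair shown, so its contribution remains unknown.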